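Aryl Ketone Variation on a Shared Benzothiazole Enaminone Core

The source may hold more compounds than are shown below. What is called first, only, known or untested is meant among the compounds shown, and "the series" means these compounds.

Compound 1 `COc1ccc2nc(-c3ccc(N/C=C\C(=O)c4ccc(OC)c(O)c4)c(C)c3)sc2c1`: 17000 nM
Compound 2 `COc1cc(C(=O)/C=C\Nc2ccc(-c3nc4cc(OC)c(OC)c(OC)c4s3)cc2C)cc(OC)c1OC`: 22800 nM
Compound 3 `COc1ccc2nc(-c3ccc(N/C=C\C(=O)c4ccc(OC)c([N+](=O)[O-])c4)c(C)c3)sc2c1`: 23600 nM

In a functional assay on MIA PaCa-2 cells (Homo sapiens) for antiproliferative activity, read by sulforhodamine B assay, with a stated time of 48 h (on this read-out higher numbers stand for weaker inhibition and lower numbers for stronger inhibition), compound 2 gives 22800 nM. Its number lies within the scatter of compound 3, which gives 23600 nM, and of compound 1, which gives 17000 nM; the three compounds cannot be told apart on this read-out.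

Compound 4 `COc1ccc(C(=O)/C=C\Nc2ccc(-c3nc4cc(OC)c(OC)c(OC)c4s3)cc2C)cc1F` is not yet measured. It differs from compound 2 in one place: 3-fluoro-4-methoxyphenyl in place of 3,4,5-trimethoxyphenyl on a carbonyl carbon

Among the compounds with values here, the only single-place step measured so far, a 1.4-fold higher number from compound 1 to compound 3 (0.14 log units; within the scatter), also alters the aryl ketone ring, and it stayed within the scatter. Within the data shown here, no step between compounds that share the core of compound 2 has been measured. Since every change at the aryl ketone seen here left the number where it was, compound 4 is expected to stay close to compound 2, with a 1.1-fold lower number from compound 2 to compound 4 (0.06 log units; within the scatter) as the expected step. The estimate for compound 4 in this assay is 20000 nM, within a range from 8000 nM to 50000 nM.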

Compound 4, half-maximal inhibitory concentration: 1800 nM
Beside the measured number, compound 4's estimate is 11-fold (1.05 log units) above it, outside the stated range (below it).
By their numbers in this assay, from the lowest: compound 4; then compounds 1, 2 and 3 (each within the scatter of the next).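

In this assay, the aryl group on a carbonyl carbon proves able to move the number substantially, with a 13-fold lower number from compound 2 to compound 4 (1.10 log units; beyond the scatter), whereas the earlier step at this aryl ketone, a 1.4-fold higher number from compound 1 to compound 3 (0.14 log units; within the scatter), stayed within the scatter. The change replaces 3,4,5-trimethoxyphenyl with 3-fluoro-4-methoxyphenyl, so the position is sensitive to at least this exchange of substituents on the ring. No available evidence bears on the reason for this gain.

This one step removes methoxy groups and introduces fluorine together, so the contribution of each remains unresolved. As far as these compounds go, it also remains open whether a chlorine or an amine in place of the fluorine would give a similar number, and whether 3-fluoro-4-methoxyphenyl would have the same effect on the core of compound 1.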